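Ring size on the aromatic carbon: compound 3 to compound 4

The source may hold more compounds than are shown below. What is called first, only, known or untested is meant among the compounds shown, and "the series" means these compounds.

Measured so far, in a functional assay on Jurkat cells (Homo sapiens) for inhibition, read by MTT assay, with a stated time of 72 h; on this read-out higher numbers stand for weaker inhibition of growth and lower numbers for stronger inhibition of growth:
compound 1 `COC(=O)c1nc(C)n(-c2ccc(C(F)(F)F)cc2)n1` gives 9100 nM
compound 2 `COC(=O)c1nc(C2CCCCC2)n(-c2ccc(F)cc2)n1` gives > 100000 nM, a limit of the assay
compound 3 `COC(=O)c1nc(C2CCCC2)n(-c2ccc(C(F)(F)F)cc2)n1` gives > 100000 nM, a limit of the assay

Compound 3 stands at the limit of > 100000 nM in this assay, at which 2 of the 3 values shown sit; for compound 3 only a limit is known, not a number. Going by the values given here, compound 1 is the one compound of the three with a numeric value, and the one step that connects it to the rest is an at least 10-fold higher number from compound 1 to compound 3 (1.04 log units; beyond the scatter), which carries the value past the limit.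

Compound 4 `COC(=O)c1nc(C2CCCCC2)n(-c2ccc(C(F)(F)F)cc2)n1` differs from compound 3 by cyclohexyl in place of cyclopentyl on an aromatic carbon. Among the compounds with values here, no measured step covers this exact change. What bears on it is that replacing methyl by a carbon ring, in an at least 10-fold higher number from compound 1 to compound 3 (1.04 log units; beyond the scatter), already moved the value past the limit. Compound 2 also carries cyclohexyl on an aromatic carbon and sits at the limit. Between compound 2 and compound 4 no step is computed, so their values can only be set side by side.

The expected step in this assay is therefore a number no higher from compound 3 to compound 4 (the limit leaves the size open), none beyond the scatter, and compound 4 is most likely reported as a limit again. The estimate for compound 4 is 100000 nM, with a range from 50000 nM to 300000 nM.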

Compound 4, concentration for 50% growth inhibition: > 100000 nM
Compound 4 gave a limit, no number; the forecaster's own chance of this, stated with the estimate: 85%; the middle value lies on the limit itself.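

In this assay, putting cyclohexyl where compound 1 carries methyl gives an at least 10-fold higher number from compound 1 to compound 4 (1.04 log units; beyond the scatter), so with trifluoromethyl held constant, the five-membered and the six-membered carbon ring both end at the limit, and the loss of a numeric value at this position is no longer tied to cyclopentyl alone. Compound 4 gives > 100000 nM, which is a limit and not a number. The steps to compound 4 from compound 3 and from compound 2 cannot be read, so neither cyclohexyl against cyclopentyl nor trifluoromethyl against fluoro can be ranked in this series, and the values gather at one point: the limit of > 100000 nM in this assay, at which 3 of the 4 values shown sit.

From the compounds shown here alone, compound 1 remains the only numeric anchor, and the position is described only by methyl and by the two carbon rings; whether ethyl, isopropyl or cyclopropyl on this aromatic carbon keeps a numeric value remains open. Also open, going by these compounds, is whether the fluoro and trifluoromethyl groups differ at all when methyl sits on this carbon, since the pair at hand differs only where both values are limits.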